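The source may report more compounds than this note shows. Statements on the series, on what has been measured and on what is new or still open speak of the compounds shown alone.

Measured compounds:
compound 1 `CCOC(=O)c1ccc(/N=N/N(C)C(=O)[C@H](C)NC(C)=O)cc1`, in a physicochemical assay for metabolic stability, read by HPLC, in phosphate buffer, at pH 7.7 (on this read-out lower numbers stand for a shorter-lived compound and higher numbers for a longer-lived compound), compound 1 gives 15.7 h
compound 2 `CCCC(=O)N[C@@H](C)C(=O)N(C)/N=N/c1ccc(C#N)cc1`, in this assay compound 2 gives 9.1 h

Compound 2 has the lower of the two half-lives, though its gap to compound 1 lies within the scatter, so the two stand level. Compound 3 `CC(=O)N[C@@H](C)C(=O)N(C)/N=N/c1ccc(C#N)cc1` differs from compound 2 by hydrogen in place of ethyl on a saturated chain carbon bound to a carbonyl carbon. Within the data shown here, no comparable step between measured compounds exists here, so the expectation rests on the shared core alone: a step from compound 2 to compound 3 of no more than the scatter, in no clear direction, is expected in this assay, meaning a 1.0-fold higher number from compound 2 to compound 3 (0.02 log units; within the scatter). Compound 3 is therefore expected to give 9.5 h, in a range from 5 h to 18 h.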

Compound 3, half-life: 9.8 h
Estimate against measurement, compound 3: 1.0-fold (0.01 log units) below; the range from low to high includes it.
By their numbers in this assay, from the lowest: compounds 2, 3 and 1 (each within the scatter of the next).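

In this assay, hydrogen in place of ethyl on a saturated chain carbon bound to a carbonyl carbon gives a 1.1-fold higher number from compound 2 to compound 3 (0.03 log units; within the scatter) and so leaves no readable mark on the half-life at this position. Compound 3 also provides a second one-place comparison: cyano in place of ethoxycarbonyl on an aromatic carbon gives a 1.6-fold lower number from compound 1 to compound 3 (0.20 log units; within the scatter) and likewise cannot be read as a change. Nothing available explains why these half-lives stand level. Still open, from the compounds shown here alone, is whether a longer chain at the first position, or an amine or carboxylic acid at the aromatic carbon, would move the half-life beyond the scatter.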